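Ether and ester groups on the shared core

A few compounds are considered here, and "the series" means these few. Any claim that something is new, unique, unknown or untested is made for them only; others in the source may bear on it.

In a functional assay on HL-60 cells (Homo sapiens) for cytotoxicity, read by MTT assay, with a stated time of 24 h (a lower number here means a stronger inhibitor, a higher number a weaker inhibitor), compound 1 (`OCCCOc1c(Br)cc(Br)cc1Oc1ccc(Br)cc1Br`) gives 29.9 ug/mL and compound 2 (`CC(=O)Oc1c(Br)cc(Br)cc1Oc1ccc(Br)cc1Br`) gives 29.9 ug/mL while compound 3 (`CCOC(=O)C(C)Oc1c(Br)cc(Br)cc1Oc1ccc(Br)cc1Br`) gives 35.7 ug/mL in the same read-out. Compound 3 therefore lies within the scatter of both other compounds. Compound 4 (`CC(C)(C)C(=O)C(C#N)Oc1c(Br)cc(Br)cc1Oc1ccc(Br)cc1Br`) differs from it as follows: cyano((tert-butyl)carbonyl)methyl in place of 1-(ethoxycarbonyl)ethyl on an oxygen on an aromatic ring on an oxygen on an aromatic ring. The measured steps at that oxygen are no change at the digits printed from compound 1 to compound 2 (within the scatter) and a 1.2-fold higher number from compound 1 to compound 3 (0.08 log units; within the scatter) and a 1.2-fold higher number from compound 2 to compound 3 (0.08 log units; within the scatter) and all three stay within the scatter. For the measured compounds named here, no measured compound carries the entering group, so this support is indirect. No step beyond the scatter is expected in this assay for this change. The expected size is a 1.1-fold lower number from compound 3 to compound 4 (0.05 log units; within the scatter) and it would stay within the scatter. For compound 4 the expected value is 32 ug/mL with a range of 15 ug/mL to 60 ug/mL as an estimate.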

Compound 4, half-maximal inhibitory concentration: 29.2 ug/mL
The estimate for compound 4 lay 1.1-fold (0.04 log units) above the measured number; measured number inside the range.
By their numbers in this assay, from the lowest: compounds 4, 1, 2 and 3 (each within the scatter of the next).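

In this assay the cyano((tert-butyl)carbonyl)methyl group, the first at this oxygen to carry a nitrile, stays within the scatter of all three earlier groups (a 1.2-fold lower number from compound 3 to compound 4 (0.09 log units; within the scatter)) and (a 1.0-fold lower number from compound 2 to compound 4 (0.01 log units; within the scatter)) and (a 1.0-fold lower number from compound 1 to compound 4 (0.01 log units; within the scatter)). Across these four compounds, the oxygen on an aromatic ring thus takes ether, ester and nitrile-bearing ketone groups with no step beyond the scatter. Nothing available explains this flat result. As far as these compounds go, whether an amine or a carboxylic acid on this oxygen would also stay within the scatter remains open.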